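Moving the ring out one carbon and swapping oxygen for sulfur

The compounds below may be only part of what the source reports. "The series", "measured", "known", "first", "only" and "open" are said of these compounds alone.

Compound 1 `CC(C)[C@@H](c1ccc(-c2ccc3cccc(F)c3c2)[nH]c1=O)[C@@H]1OC(=O)NC1=O`: 610 nM
Compound 2 `CC(C)C(CC1NC(=O)NC1=O)c1ccc(-c2ccc3cccc(F)c3c2)[nH]c1=O`: 31 nM
Compound 3 `O=C1NC(=O)/C(=C/C(Cc2ccccc2)c2ccc(-c3ccc4cccc(F)c4c3)[nH]c2=O)O1`: 200 nM

In a functional assay on CHO cells for antagonist activity at prostaglandin E2 receptor EP3 subtype (Homo sapiens), read by cAMP accumulation, with a stated time of 30 min (on this read-out lower numbers stand for stronger inhibition and higher numbers for weaker inhibition), compound 1 gives the highest number of the three, so it is the weakest of this set; compound 3 and compound 2 sit at clearly lower values. Compound 4 `CC(C)[C@H](C[C@H]1SC(=O)NC1=O)c1ccc(-c2ccc3cccc(F)c3c2)[nH]c1=O` keeps the core of compound 1 and differs in one place: (2,4-dioxo-1,3-thiazolidin-5-yl)methyl in place of 2,4-dioxo-1,3-oxazolidin-5-yl on a saturated chain carbon bound to an aromatic carbon and a saturated chain carbon. The nearest comparison is compound 2, where a five-membered ring held on a one-carbon linker gives 31 nM. The step from compound 1 to compound 4 is therefore expected to be a clear drop, well beyond the scatter a 12-fold lower number from compound 1 to compound 4 (1.09 log units; beyond the scatter). Compound 4 is estimated at 50 nM, with a likely range of 12 nM to 200 nM.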

Compound 4, half-maximal inhibitory concentration: 9 nM
The estimate for compound 4 lay 5.6-fold (0.74 log units) above the measured number; the whole stated range lies above it.
By their numbers in this assay, from the lowest: compound 4; then compound 2; then compound 3; then compound 1.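

On the saturated chain carbon bound to an aromatic carbon and a saturated chain carbon, (2,4-dioxo-1,3-thiazolidin-5-yl)methyl in place of 2,4-dioxo-1,3-oxazolidin-5-yl gives, in this assay, a 68-fold lower number from compound 1 to compound 4 (1.83 log units; beyond the scatter) as a large step. This position therefore responds strongly to the group it carries, even though both groups have the same counts of hydrogen-bond donors and acceptors. Nothing available explains the gain.

As far as these compounds go, the step combines an added methylene carbon with sulfur replacing oxygen, so the share of each stays unknown. From the compounds shown here alone, whether a carboxylic acid at this position would match the new group also remains open.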